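A Single Trifluoromethyl Removed from a Diaryl Urea

This account rests on a few compounds, and the source may have more. Where it says the series, first, only, none or still open, it means among the compounds named here.

Measured compounds:
compound 1 `O=C(Nc1cccc(-n2cc(-c3ccncc3)c(-c3cc(O)cc(Cl)c3)n2)c1)Nc1ccc(Cl)c(C(F)(F)F)c1` – 87%
compound 2 `O=C(Nc1cccc(-n2cc(-c3ccncc3)c(-c3cc(O)cc(Cl)c3)n2)c1)Nc1ccc(Cl)c(Cl)c1` – 57%
compound 3 `COc1cc(Cl)cc(-c2nn(-c3cccc(NC(=O)Nc4cc(C(F)(F)F)cc(C(F)(F)F)c4)c3)cc2-c2ccncc2)c1` – 50%

In a functional assay on Hs-578T cells (Homo sapiens) for inhibition, read by sulforhodamine B assay, with a stated time of 48 h, tested at 1 uM (on this read-out higher numbers stand for a weaker effect at the one concentration tested and lower numbers for a stronger effect), compound 1 gives 87%, and compound 2 gives 57%, the two differing only by the group on the terminal aryl ring of the urea; that step is a number 30 percentage points lower from compound 1 to compound 2 (beyond the scatter). Compound 3, which carries a methoxy in place of the hydroxy on the shared core and two trifluoromethyl groups on the urea aryl ring, gives 50% in this assay. Its number lies within the scatter of that of compound 2 and beyond the scatter below that of compound 1, so among the three it sits at the stronger end without being set apart from compound 2.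

Compound 4 `COc1cc(Cl)cc(-c2nn(-c3cccc(NC(=O)Nc4cccc(C(F)(F)F)c4)c3)cc2-c2ccncc2)c1` keeps the core of compound 3 and differs from it by hydrogen in place of trifluoromethyl on an aromatic carbon. For the measured compounds named here, the only measured step touching a trifluoromethyl, from compound 1 to compound 2, was modest and went toward a stronger effect, but there chloro entered, not hydrogen, so it bears on the present step only loosely. Compound 4 is therefore expected to give 62% (range 40% to 85%), a step of a number 12 percentage points higher from compound 3 to compound 4 (beyond the scatter), likely within the scatter or a small weakening.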

Compound 4, a percentage reported as activity, at one concentration (the size of the read-out at that concentration, not a potency): 90%
The estimate for compound 4 lay 28 percentage points below the measured number; measured number above the stated range.
By their numbers in this assay, from the lowest: compounds 3 and 2 (each within the scatter of the next); then compounds 1 and 4 (each within the scatter of the next).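

In this assay, taking one of the two trifluoromethyl groups off the urea aryl ring of compound 3 and leaving hydrogen gives a number 40 percentage points higher from compound 3 to compound 4 (beyond the scatter), a large step. This shows that the place on the aromatic carbon, meta to a large group and meta to a trifluoromethyl group, matters a good deal on this core: the second trifluoromethyl cannot be lost without the number rising. The earlier step, a number 30 percentage points lower from compound 1 to compound 2 (beyond the scatter), swapped a trifluoromethyl for chloro on the core of compound 1, so it could show only an exchange of one group for another, not what happens when the place is left with hydrogen, and nothing available here explains the size of the new step.

From the compounds shown here alone, what remains open is whether this place calls for a trifluoromethyl in particular, or whether a nitrile or a methyl there would keep the number close to that of compound 3 at 50%. Also open, going by these compounds, is whether the same change to hydrogen would give a step of similar size on the hydroxy-bearing core of compound 1.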